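The source may hold more compounds than are shown below. What is called first, only, known or untested is meant among the compounds shown, and "the series" means these compounds.

Compound 2 `COc1ccc2cc(CCCO)oc(=O)c2c1` is the point of departure. In a functional assay on 786-0 cells (Homo sapiens) for antiproliferative activity, read by sulforhodamine B assay, with a stated time of 48 h (on this read-out lower numbers stand for stronger inhibition of growth and higher numbers for weaker inhibition of growth), compound 2 gives 26.9 ug/mL, the lowest of the two numbers recorded so far, and compound 1 `COc1ccc2cc(CO)oc(=O)c2c1` gives 37.6 ug/mL. Among the compounds with values here, the only measured step, a 1.4-fold lower number from compound 1 to compound 2 (0.15 log units; within the scatter), came with 2-hydroxyethyl in place of hydroxy on a saturated chain carbon bound to an aromatic carbon.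

Compound 3 `CCCCCOCCCc1cc2ccc(OC)cc2c(=O)o1` differs from compound 2 by pentyl in place of hydrogen on an oxygen on a saturated carbon. Within the data shown here, no measured step bears on this change, since the one known step altered the chain and not the oxygen on it, and that step stayed within the scatter. With nothing to guide a direction, a step of a 1.2-fold lower number from compound 2 to compound 3 (0.09 log units; within the scatter) is expected, with no change beyond the scatter. Compound 3 is therefore estimated at 22 ug/mL in this assay, within a range of 7 ug/mL to 70 ug/mL.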

Compound 3, concentration for 50% growth inhibition: 25.5 ug/mL
Beside the measured number, compound 3's estimate is 1.2-fold (0.06 log units) below it; the measured number falls inside the stated range.
By their numbers in this assay, from the lowest: compounds 3, 2 and 1 (each within the scatter of the next).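

Replacing the hydrogen on this oxygen with pentyl, which turns hydroxy into pentyloxy, gave a 1.1-fold lower number from compound 2 to compound 3 (0.02 log units; within the scatter) in this assay, so this change of five carbons left the read-out within the scatter. The earlier compounds shown here differed only in the chain and both kept the hydroxy, whereas compound 3 shows that the hydrogen on this oxygen can be replaced without a change in growth inhibition beyond the scatter. Nothing available explains why the read-out stays so flat at this position.

As far as these compounds go, it remains open whether an amine or a carboxylic acid in place of the hydroxy would move the number beyond the scatter. A chain longer than pentyl, or a phenyl ring in place of pentyl on the same oxygen, is equally untested by the compounds shown.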